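Sulfonylguanidine Series: Chloro to Trifluoromethyl Swap

A few compounds are considered here, and "the series" means these few. Any claim that something is new, unique, unknown or untested is made for them only; others in the source may bear on it.

Measured so far:
compound 1 `Cc1cc(S(=O)(=O)/N=C(\N)n2nccc2-c2ccccc2)c(SCc2ccc(Cl)cc2)cc1Cl`: 75000 nM
compound 2 `Cc1cc(-c2ccccc2)n(/C(N)=N/S(=O)(=O)c2cc(C)c(Cl)cc2SCc2ccccc2C)n1`: 80000 nM

In a functional assay on MCF7 cells (Homo sapiens) for cytotoxicity, read by MTT assay, with a stated time of 72 h (on this read-out higher numbers stand for weaker inhibition and lower numbers for stronger inhibition), compound 1 stands at 75000 nM. Compound 2 gives 80000 nM, a difference within the scatter, so the two cannot be ranked. Compound 3 `Cc1cc(S(=O)(=O)/N=C(\N)n2nccc2-c2ccccc2)c(SCc2ccc(C(F)(F)F)cc2)cc1Cl` is not yet measured; it differs from compound 1 by trifluoromethyl in place of chloro on an aromatic carbon. Within the data shown here, no step between measured compounds is available, so no size of step can be read from the data. The step of a 1.1-fold lower number from compound 1 to compound 3 (0.03 log units; within the scatter) is expected to lie within the scatter, in no particular direction. Compound 3 is estimated at 70000 nM, range 30000 nM to 160000 nM.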

Compound 3, half-maximal inhibitory concentration: 25000 nM
Beside the measured number, compound 3's estimate is 2.8-fold (0.45 log units) above it, outside the stated range (below it).
By their numbers in this assay, from the lowest: compound 3; then compounds 1 and 2 (each within the scatter of the next).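

Among these compounds, the (4-chlorobenzyl)sulfanyl part of the core is sensitive to change at this aromatic carbon: in this assay, trifluoromethyl in place of chloro gives a 3.0-fold lower number from compound 1 to compound 3 (0.48 log units; beyond the scatter), the first step that can be read. The step is modest, and it shows that this position can shift the number beyond the scatter. No data bearing on the cause of the step are available.

Going by these compounds, it remains open whether a nitrile, a methoxy group or an amine on this aromatic carbon would lower the number further or raise it again.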